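A Pyridine for a Furan on a Shared Core

This account rests on a few compounds, and the source may have more. Where it says the series, first, only, none or still open, it means among the compounds named here.

compound 1 `c1cc(CNC2CCN(CCCc3c[nH]c4ccc(-n5cnnc5)cc34)CC2)co1`: 4.5 nM
compound 2 `C[C@@H](NC1CCN(CCCc2c[nH]c3ccc(-n4ccnc4)cc23)CC1)c1ccccc1`: 4.2 nM

In an assay on CHO cells for displacement of a labelled ligand from 5-hydroxytryptamine receptor 1D (Homo sapiens) (on this read-out lower numbers stand for stronger inhibition and higher numbers for weaker inhibition), compound 1 gives 4.5 nM, the higher of the two numbers, and compound 2 gives 4.2 nM; the two values lie within the scatter of each other, so neither can be set ahead. Compound 3 `c1cncc(CNC2CCN(CCCc3c[nH]c4ccc(-n5cnnc5)cc34)CC2)c1` differs from compound 1 in one place: pyridin-3-yl in place of furan-3-yl on a saturated chain carbon bound to an amine nitrogen. The ((furan-3-yl)methyl)amino of compound 1 thus becomes a ((pyridin-3-yl)methyl)amino. Among the measured compounds shown here, no measured pair shows this exchange, so the step is estimated as a 1.3-fold higher number from compound 1 to compound 3 (0.12 log units; within the scatter), a small rise in the number, not clearly beyond the scatter. Compound 3 is expected to give 6 nM, with a range from 2 nM to 18 nM.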

Compound 3, half-maximal inhibitory concentration: 35 nM
For compound 3 the middle estimate is 5.8-fold (0.77 log units) below the measured one, outside the stated range (above it).
By their numbers in this assay, from the lowest: compounds 2 and 1 (each within the scatter of the next); then compound 3.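

In this assay, pyridin-3-yl in place of furan-3-yl on a saturated chain carbon bound to an amine nitrogen gives a 7.8-fold higher number from compound 1 to compound 3 (0.89 log units; beyond the scatter). Among the compounds shown here, this is the first sign that the ring at this position matters on the shared core, since a swap of one aromatic ring for another is enough to move the number beyond the scatter. Nothing measured here accounts for the step.

From the compounds shown here alone, whether it follows the larger ring or the ring nitrogen stays open, and thiophen-3-yl or pyridin-4-yl at this place would bear on that. This single pair also cannot say whether the step would hold on another core.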